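Substance-P receptor series: from compound 3 to compound 4

The source may hold more compounds than are shown below. What is called first, only, known or untested is meant among the compounds shown, and "the series" means these compounds.

Measured so far:
compound 1, `C[C@@H](O[C@@H]1[C@@H](c2ccccc2)CN(C(=O)OC(C)(C)C)[C@H]1CO)c1cc(C(F)(F)F)cc(C(F)(F)F)c1`, 3.6 nM
compound 2, `C[C@@H](O[C@H]1[C@H](c2ccccc2)CN(C(=O)OC(C)(C)C)[C@H]1CO)c1cc(C(F)(F)F)cc(C(F)(F)F)c1`, 7.8 nM
compound 3, `C[C@@H](O[C@H]1CN2C(=O)N(C)C[C@H]2[C@@H]1c1ccc(F)cc1)c1cc(C(F)(F)F)cc(C(F)(F)F)c1`, 0.88 nM

In an assay on CHO cells for displacement of a labelled ligand from Substance-P receptor (Homo sapiens) (a higher number here means a weaker inhibitor, a lower number a stronger inhibitor), compound 3 gives the lowest number of the three, with compound 1 the nearest and compound 2 the furthest. Within the data shown here, the one step between compounds that differ in a single place is a 2.2-fold higher number from compound 1 to compound 2 (0.34 log units; beyond the scatter); it rests on the fact that compounds 1 and 2 differ only in the configuration as drawn and concerns configuration only, not a change of substituent. Compound 4, `C[C@@H](O[C@H]1CN2C(=O)N(Cc3ccccc3)C[C@H]2[C@@H]1c1ccc(F)cc1)c1cc(C(F)(F)F)cc(C(F)(F)F)c1`, carries phenyl in place of hydrogen on a saturated chain carbon bound to an amide-type nitrogen in a ring. Among the measured compounds shown here, no measured step bears on such a change, so there is no precedent for its direction or size; from compound 3 a step within the scatter, or at most a modest one either way, is expected: a 1.4-fold higher number from compound 3 to compound 4 (0.13 log units; within the scatter). Compound 4 is therefore estimated at 1.2 nM, in the range 0.4 nM to 4 nM.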

Compound 4, half-maximal inhibitory concentration: 2.7 nM
The estimate for compound 4 lay 2.3-fold (0.35 log units) below the measured number; measured number inside the range.
By their numbers in this assay, from the lowest: compound 3; then compounds 4 and 1 (each within the scatter of the next); then compound 2.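

Among these compounds, replacing methyl with benzyl on this saturated chain carbon bound to an amide-type nitrogen in a ring gives the first substituent step: in this assay, a 3.1-fold higher number from compound 3 to compound 4 (0.49 log units; beyond the scatter). Among the compounds shown here, the earlier compounds offered only a step in configuration, so this is the first sign that the position accepts a phenyl at a modest cost in binding. Nothing on hand accounts for the size or direction of this step.

Still open, as far as these compounds go, is how a longer chain, such as phenethyl, would compare with benzyl. Also open, from the compounds shown here alone, is what a carboxylic acid or an amine on the phenyl would do.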